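The source may hold more compounds than are shown below. What is called first, only, known or untested is meant among the compounds shown, and "the series" means these compounds.

Series notes. Of the compounds shown here, two on the shared core carry a measured value so far. In a functional assay on DU-145 cells (Homo sapiens) for inhibition, read by trypan blue exclusion, with a stated time of 72 h (a higher number here means a weaker inhibitor, a lower number a stronger inhibitor), compound 1 `Cn1c(=O)c(S(=O)(=O)c2ccc(F)cc2F)cc2cnc(Nc3ccc4[nH]c(C(=O)O)cc4c3)nc21` gives 10000 nM, the higher of the two numbers recorded. Compound 2 `Cn1c(=O)c(S(=O)(=O)c2ccc(F)cc2[N+](=O)[O-])cc2cnc(Nc3ccc4[nH]ccc4c3)nc21` differs from compound 1 in several positions; in this assay compound 2 gives 1500 nM. The gap between compound 1 and compound 2 lies beyond the scatter, so compound 1 stands as the weaker of the pair. Compound 3 `Cn1c(=O)c(S(=O)(=O)c2ccc(F)cc2F)cc2cnc(Nc3ccc4c(c3)C(=O)C(=O)N4)nc21` has not yet been measured. It differs from compound 1 in one place: a group of 11 heavy atoms (8 carbon, 1 nitrogen, 2 oxygen; one five-membered non-aromatic ring with 1 hetero atom, one six-membered aromatic ring of carbon only) in place of a group of 12 heavy atoms (9 carbon, 1 nitrogen, 2 oxygen; one five-membered aromatic ring with 1 hetero atom, one six-membered aromatic ring of carbon only), on a nitrogen on an aromatic ring. Among the compounds with values here, no step between measured compounds covers this change, and compound 2 varies elsewhere as well, so it offers no direct guide. A modest move toward a lower number is expected, a 2.0-fold lower number from compound 1 to compound 3 (0.30 log units; within the scatter), a step of about the size of the scatter. Compound 3 is estimated to give roughly 5000 nM in this assay, with a range from 1500 nM to 15000 nM.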

Compound 3, half-maximal inhibitory concentration: 75000 nM
Beside the measured number, compound 3's estimate is 15-fold (1.18 log units) below it, outside the stated range (above it).
By their numbers in this assay, from the lowest: compound 2; then compound 1; then compound 3.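

In this assay, within the data shown here, the place on a nitrogen on an aromatic ring proves sensitive: putting the group with a five-membered non-aromatic ring and two double bonds outside aromatic rings in place of 2-carboxy-1H-indol-5-yl gives a 7.5-fold higher number from compound 1 to compound 3 (0.88 log units; beyond the scatter), the first single-place step. The two groups are close in heavy-atom count and both keep a six-membered aromatic ring of carbon only, yet they are not interchangeable here. No measurement at hand bears on what lies behind this step.

The change alters the five-membered ring and removes the carboxy group at once, so the contribution of each remains unresolved. A methyl ester or a primary amide in place of the carboxy group, on an otherwise unchanged 2-carboxy-1H-indol-5-yl framework, would bear on that question.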